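Adding a second fluoro to compound 3

The compounds below may be only part of what the source reports. "The series", "measured", "known", "first", "only" and "open" are said of these compounds alone.

Values measured so far in a functional assay with Homo sapiens as the target (on this read-out lower numbers stand for stronger inhibition and higher numbers for weaker inhibition), are these.
- compound 1 `CC(C)[C@H](NC(=O)COc1cccc2ccccc12)C(=O)N[C@@H](CC(=O)O)C(=O)COc1cccc2ccccc12` gives 19000 nM
- compound 2 `CC(C)[C@H](NC(=O)COc1cccc2ccccc12)C(=O)N[C@@H](CC(=O)O)C(=O)COc1ccc(C#N)cc1` gives 26700 nM
- compound 3 `CC(C)[C@H](NC(=O)COc1cccc2ccccc12)C(=O)N[C@@H](CC(=O)O)C(=O)COc1ccc(F)cc1` gives 14300 nM

Compound 3 at 14300 nM lies within the scatter of both other compounds, so these three cannot be ranked. The next compound is compound 4 `CC(C)[C@H](NC(=O)COc1cccc2ccccc12)C(=O)N[C@@H](CC(=O)O)C(=O)COc1ccc(F)c(F)c1`. It turns 4-fluorophenoxy into 3,4-difluorophenoxy, with fluoro in place of hydrogen on an aromatic carbon, ortho to a fluoro group and meta to a large group (fluoro in place of hydrogen on an aromatic carbon). Going by the values given here, no measured step adds a second group to this ring, so the evidence is indirect. Exchanging one group on the ring gave a 1.9-fold lower number from compound 2 to compound 3 (0.27 log units; within the scatter) and replacing the whole naphthalen-1-yl group gave a 1.3-fold lower number from compound 1 to compound 3 (0.12 log units; within the scatter), and both steps are small. Even these larger exchanges stayed within the scatter, so a smaller edit is not expected to move this assay beyond it. The expected change is a 1.0-fold higher number from compound 3 to compound 4 (0.02 log units; within the scatter) with no clear direction. For compound 4 the estimated value is 15000 nM, with an expected range from 8000 nM to 28000 nM in this assay as well.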

Compound 4, half-maximal inhibitory concentration: 16200 nM
Beside the measured number, compound 4's estimate is 1.1-fold (0.03 log units) below it; low and high end bracket the measured number.
By their numbers in this assay, from the lowest: compounds 3, 4, 1 and 2 (each within the scatter of the next).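

In this assay, going by these compounds alone, the second fluoro gives a 1.1-fold higher number from compound 3 to compound 4 (0.05 log units; within the scatter) and so offers the first direct reading of an added group on this ring: fluoro in place of hydrogen, ortho to a fluoro group, leaves the number within the scatter. The 3,4-difluorophenyl group also stays within the scatter of the other two groups compared on this oxygen, with a 1.6-fold lower number from compound 2 to compound 4 (0.22 log units; within the scatter) and a 1.2-fold lower number from compound 1 to compound 4 (0.07 log units; within the scatter) as the steps, so the four compounds still cannot be ranked. Nothing available explains why these exchanges leave the number so little changed.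

The compounds shown leave open whether a methoxy group or an amine in this same place would move the number beyond the scatter. They also leave open whether a third fluoro on this ring would do so.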